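Adding a Cyano Group to the Fused Ring of Compound 2

This account rests on a few compounds, and the source may have more. Where it says the series, first, only, none or still open, it means among the compounds named here.

The measured compounds in an ADME assay on C8166 cells (Homo sapiens) for cytotoxicity, read by colorimetric assay and MTT assay; a lower number here means that less compound is tolerated, a higher number that more compound is tolerated:
compound 1 `Cc1cc(S(N)(=O)=O)ccc1NC(=O)COc1ccc2ccccc2c1C(=O)c1ccccc1`, 33800 nM
compound 2 `Cc1cc(C)cc(C(=O)c2c(OCC(=O)Nc3ccc(S(N)(=O)=O)cc3C)ccc3ccccc23)c1`, 39100 nM
compound 3 `Cc1cc(S(N)(=O)=O)ccc1NC(=O)COc1ccc2ccccc2c1C(=O)c1cc(Cl)cc(Br)c1`, 36600 nM

Compound 2 shows the top number of the three, but only within the scatter: a 1.1-fold lower number from compound 2 to compound 3 (0.03 log units; within the scatter), and a 1.2-fold higher number from compound 1 to compound 2 (0.06 log units; within the scatter). Compound 4 `Cc1cc(C)cc(C(=O)c2c(OCC(=O)Nc3ccc(S(N)(=O)=O)cc3C)ccc3cc(C#N)ccc23)c1` differs from compound 2 in one place: cyano in place of hydrogen on an aromatic carbon. Going by the values given here, none of the measured steps touches this ring; they change the aryl on the carbonyl carbon, and all stayed within the scatter: a 1.2-fold higher number from compound 1 to compound 2 (0.06 log units; within the scatter), a 1.1-fold higher number from compound 1 to compound 3 (0.03 log units; within the scatter), a 1.1-fold lower number from compound 2 to compound 3 (0.03 log units; within the scatter). Nothing in these data bears directly on the cyano group, so the expected step is a 1.1-fold lower number from compound 2 to compound 4 (0.02 log units; within the scatter), no change beyond the scatter. Compound 4 is therefore estimated at 37000 nM, in a range from 18000 nM to 75000 nM.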

Compound 4, half-maximal cytotoxic concentration: 128000 nM
For compound 4 the middle estimate is 3.5-fold (0.54 log units) below the measured one; measured number above the stated range.
By their numbers in this assay, from the lowest: compounds 1, 3 and 2 (each within the scatter of the next); then compound 4.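

The fused ring of the shared core proves to be a place where this assay responds: cyano in place of hydrogen on this aromatic carbon gives a 3.3-fold higher number from compound 2 to compound 4 (0.52 log units; beyond the scatter). This is the only step shown that lies beyond the scatter, since the aryl changes on the carbonyl carbon all stayed within it. Nothing available accounts for this rise.

Going by these compounds, whether an amine, a carboxylic acid or a methoxy group on the same carbon would also shift the number remains open. So does whether cyano does the same alongside the phenyl of compound 1.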